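Adding a Methoxy to a Weak Compound

This account rests on a few compounds, and the source may have more. Where it says the series, first, only, none or still open, it means among the compounds named here.

Values in a functional assay on CCRF-CEM cells (Homo sapiens) for antiproliferative activity, read by cell counting, with a stated time of 2 days; on this read-out lower numbers stand for stronger inhibition and higher numbers for weaker inhibition:
Compound 1 `COc1ccc(Nc2nc(N)c(C(=O)c3ccccc3)s2)cc1`: 300 nM
Compound 2 `COc1ccc(Nc2nc(N)c(C(=O)c3ccc(Cl)cc3)s2)cc1`: 19 nM
Compound 3 `COc1ccccc1C(=O)c1sc(Nc2ccccc2)nc1N`: 730 nM

Among these three, compound 3 is the weakest, with the highest number at 730 nM. Compound 1 reads 300 nM and compound 2 reads 19 nM.

The next compound is compound 4 `COc1ccc(Nc2nc(N)c(C(=O)c3ccccc3OC)s2)cc1`, which has not yet been measured. It comes from compound 3 through one small edit: methoxy in place of hydrogen on an aromatic carbon. In short, methoxy takes the place of hydrogen on an aromatic carbon, turning a phenyl into a 4-methoxyphenyl.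

Within the data shown here, no measured step matches this change. Among the measured compounds shown here, the only step available is large, a 16-fold lower number from compound 1 to compound 2 (1.20 log units; beyond the scatter), but it brings in chloro rather than methoxy, so it says little here. The closer hint is that compound 1 already carries the 4-methoxyphenyl group and reads 300 nM. However, compound 1 also differs from compound 3 elsewhere, so this hint is weak.

A modest move towards a lower number therefore seems likely in this assay, though it may barely clear the usual scatter. The expected step is a 2.4-fold lower number from compound 3 to compound 4 (0.39 log units; beyond the scatter). For compound 4 the estimated value is 300 nM, with an expected range of 60 nM to 1500 nM.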

Compound 4, half-maximal inhibitory concentration: 17 nM
Estimate against measurement, compound 4: 18-fold (1.25 log units) above; measured number below the stated range.
By their numbers in this assay, from the lowest: compounds 4 and 2 (each within the scatter of the next); then compound 1; then compound 3.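

The new result shows that this aromatic position is far from indifferent: in this assay the change from phenyl to 4-methoxyphenyl gives a 43-fold lower number from compound 3 to compound 4 (1.63 log units; beyond the scatter) when the carbonyl carries a 2-methoxyphenyl group. Seen from the other side, adding the methoxy that makes this 2-methoxyphenyl group gives an 18-fold lower number from compound 1 to compound 4 (1.25 log units; beyond the scatter) with the 4-methoxyphenyl group in place, and the 2-methoxyphenyl and 4-chlorophenyl groups on the carbonyl carbon cannot be told apart, with a 1.1-fold lower number from compound 2 to compound 4 (0.05 log units; within the scatter) lying within the scatter. No measurement here explains why a single methoxy has so large an effect on this read-out.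

The compounds shown leave open whether the phenyl to 4-methoxyphenyl change would have as large an effect with a plain phenyl or a 4-chlorophenyl group on the carbonyl, since its size is known here only with the 2-methoxyphenyl group present. They also leave open whether the methoxy of the 4-methoxyphenyl group could give way to a longer chain such as ethoxy, or to an amine such as dimethylamino, and keep a comparably low number.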